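Thiophen-2-yl in place of amino: expectations for compound 4

A few compounds are considered here, and "the series" means these few. Any claim that something is new, unique, unknown or untested is made for them only; others in the source may bear on it.

Values in a functional assay on HCT-116 cells (Homo sapiens), read by MTT assay, with a stated time of 3 days; on this read-out higher numbers stand for weaker inhibition and lower numbers for stronger inhibition:
- compound 1 `CN(C)c1ncnc2[nH]cc(Sc3cccs3)c12`: 27500 nM
- compound 2 `CNc1ncnc2[nH]cc(Sc3cccs3)c12`: 45300 nM
- compound 3 `Nc1ncnc2[nH]cc(Sc3cccs3)c12`: > 50000 nM

Compound 3 has only a limit to show, not a number: the limit of > 50000 nM in this assay, at which 1 of the 3 values shown sits.

Compound 4 `c1csc(Sc2c[nH]c3ncnc(-c4cccs4)c23)c1` differs from compound 3 by thiophen-2-yl in place of amino on an aromatic carbon. The measured steps that bear on this change all vary the group on that same carbon: a 1.6-fold higher number from compound 1 to compound 2 (0.22 log units; within the scatter), an at least 1.8-fold higher number from compound 1 to compound 3 (0.25 log units; that floor lies within the scatter) and an at least 1.1-fold higher number from compound 2 to compound 3 (0.04 log units; that floor lies within the scatter). All three stay within the scatter, so varying the methyl groups on the amino nitrogen has not moved this assay measurably. Among the measured compounds shown here, no measured compound carries thiophen-2-yl in that place, so these steps serve only as a loose guide. For the measured compounds named here, the only numbers available come from compound 1 at 27500 nM and compound 2 at 45300 nM. Nothing measured lies far from the limit of compound 3. A modest step towards a lower number is therefore expected, with a real chance that compound 4 also ends at the limit. The expected step is an at least 2.0-fold lower number from compound 3 to compound 4 (0.30 log units; that floor lies within the scatter). For compound 4 the estimate is 25000 nM, with an expected range of 8000 nM to 50000 nM.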

Compound 4, half-maximal inhibitory concentration: 5060 nM
Beside the measured number, compound 4's estimate is 4.9-fold (0.69 log units) above it; measured number outside the range, below it.
By their numbers in this assay, from the lowest: compound 4; then compounds 1 and 2 (each within the scatter of the next). At a limit, above all of these: compound 3.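

In this assay, among the compounds shown here, thiophen-2-yl on this aromatic carbon gives the first steps that lie beyond the scatter: a 9.0-fold lower number from compound 2 to compound 4 (0.95 log units; beyond the scatter) and a 5.4-fold lower number from compound 1 to compound 4 (0.74 log units; beyond the scatter). The third step, an at least 9.8-fold lower number from compound 3 to compound 4 (0.99 log units; beyond the scatter), is only a floor, since compound 3 has a limit and not a number: the limit of > 50000 nM in this assay, at which 1 of the 4 values shown sits. The position is therefore not insensitive: exchanging methyl for hydrogen on the amino nitrogen left compound 1 and compound 2 within the scatter of each other, whereas thiophen-2-yl makes compound 4 the strongest of the four in this assay.

Thiophen-2-yl is the only aromatic ring shown on this carbon, so the compounds leave open whether the lower number belongs to that ring, to its sulfur or to the loss of the amino nitrogen; phenyl, furan-2-yl or a small alkyl group such as ethyl would help to separate these. From the compounds shown here alone, with only this assay at hand, it also stays open whether the step holds in other cell lines or reflects a general effect on cells.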